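The source may report more compounds than this note shows. Statements on the series, on what has been measured and on what is new or still open speak of the compounds shown alone.

Compound 1, `CCCN(CCC)c1ccc(NC(=O)c2cc(Cl)ccc2O)c(Cl)c1`: 10700 nM
Compound 2, `CC1(ON(c2ccc(NC(=O)c3cc(Cl)ccc3O)c(Cl)c2)C2(C)CCCC2)CCCC1`: 18000 nM
Compound 3, `O=C(Nc1ccc(NCc2cc(F)cc(C(F)(F)F)c2)cc1Cl)c1cc(Cl)ccc1O`: 30900 nM

All three were tested in an ADME assay on A549 cells (Homo sapiens) for cytotoxicity, read by resazurin assay, with a stated time of 48 h; a higher number here means that more compound is tolerated, a lower number that less compound is tolerated. Compound 1 has the lowest of the three numbers. Its nearest neighbour is compound 2, whose value lies within the usual scatter of such measurements, so the two cannot be told apart on these data. Compound 3 stands further away, beyond the scatter, and is therefore tolerated at a higher concentration than compound 1.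

Compound 4, `O=C(Nc1ccc(N(CCCO)CCCO)cc1Cl)c1cc(Cl)ccc1O`, has not yet been measured in this assay. It differs from compound 1 in a single place: bis(3-hydroxypropyl)amino in place of dipropylamino on an aromatic carbon. Going by the values given here, no measured pair shows this exact change, so its effect has to be judged from the spread of the three known values, all of which lie in a fairly narrow band. On that basis the step from compound 1 to compound 4 is expected to be modest, most likely towards a somewhat higher number, and quite possibly not beyond the scatter. Compound 4 is expected to give 18000 nM in this assay, with a plausible range from 8000 nM to 40000 nM. The expected step is a 1.7-fold higher number from compound 1 to compound 4 (0.23 log units; within the scatter).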

Compound 4, half-maximal cytotoxic concentration: 114000 nM
The estimate for compound 4 lay 6.3-fold (0.80 log units) below the measured number; measured number above the stated range.
By their numbers in this assay, from the lowest: compounds 1, 2 and 3 (each within the scatter of the next, the first and the last beyond it); then compound 4.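

Within the narrow band of the three earlier compounds in this assay, nothing showed that this position, para to a large group, could shift the number by much. Putting bis(3-hydroxypropyl)amino in place of dipropylamino gives an 11-fold higher number from compound 1 to compound 4 (1.03 log units; beyond the scatter), so a change confined to this one substituent can make the compound far better tolerated while the rest of the structure stays the same. Nothing available here explains why the step is so large.

On these data alone, it remains open whether a single 3-hydroxypropyl chain on that nitrogen, beside one propyl chain, would be enough to produce a step of this kind. Also unresolved is how 3-methoxypropyl chains, which cap the oxygen with a methyl group, or chains ending in a carboxylic acid or an amine would compare.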